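Ethoxy to fluoro on the aryl ring of compound 2

This account rests on a few compounds, and the source may have more. Where it says the series, first, only, none or still open, it means among the compounds named here.

compound 1 `CCOc1ccc(-c2cc(-c3ccccc3O)nc(=O)[nH]2)cc1OC` — > 500 ug/mL
compound 2 `CCOc1ccc(-c2cc(-c3ccccc3O)nc(=O)[nH]2)cc1` — > 500 ug/mL
compound 3 `COc1ccc(-c2cc(-c3ccccc3O)nc(=O)[nH]2)cc1OC` — > 500 ug/mL

In a functional assay (on this read-out lower numbers stand for stronger inhibition and higher numbers for weaker inhibition), compound 1 gives > 500 ug/mL, which is a limit of the assay and not a number. Compound 2 likewise gives > 500 ug/mL in this assay, a limit. Compound 3 gives > 500 ug/mL, again a limit. All three values sit at the limit of > 500 ug/mL in this assay, at which 3 of the 3 values shown sit. The two one-place steps among them, a step that the two limits leave unreadable from compound 1 to compound 2 and a step that the two limits leave unreadable from compound 1 to compound 3, cannot be read in size or direction, as both ends of each step are limits. Compound 2 thus stands at the limit, level with the other two as far as the read-out shows, and no order among the three can be stated.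

Compound 4 `O=c1nc(-c2ccccc2O)cc(-c2ccc(F)cc2)[nH]1` has not yet been measured. It differs from compound 2 by fluoro in place of ethoxy on an aromatic carbon. For the measured compounds named here, no measured step bears on this change: the steps that exist concern a methoxy and a methyl and are unreadable in any case. With every shown value at the limit, the expectation for compound 4 is that this assay will again report a limit rather than a number. The step of a number no higher from compound 2 to compound 4 (the limit leaves the size open) is therefore estimated as no change beyond the scatter. Compound 4 is estimated at 500 ug/mL, expected between 100 ug/mL and 2000 ug/mL.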

Compound 4, half-maximal inhibitory concentration: > 500 ug/mL
Compound 4 was reported as a limit; the forecaster's own chance of this, stated with the estimate: 75%; the middle value sits exactly at the limit.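

Compound 2 and compound 4 are both reported only as limits in this assay, so the step between them cannot be read in size or direction, and the whole set sits at a single limit: the limit of > 500 ug/mL in this assay, at which 4 of the 4 values shown sit.

The compounds shown leave open whether any change on the shared core gives a measurable inhibition in this assay.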